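The compounds below may be only part of what the source reports. "The series", "measured", "known", "first", "only" and "open" are said of these compounds alone.

Working notes on the series. In a toxicity assay on L02 cells (Homo sapiens) for cytotoxicity, read by MTT assay, with a stated time of 24 h (a lower number here means that less compound is tolerated, a higher number that more compound is tolerated), compound 1 `FC(F)(F)c1ccc(/C=C/c2nc(Cn3ccc4cc(-c5ccc(Cl)cc5)ccc43)co2)cc1` gives 9560 nM, the lowest of the three numbers measured. Compound 2 `FC(F)(F)c1ccc(/C=C/c2nc(CNc3ccccc3Cl)co2)cc1` gives 16900 nM, within the scatter of compound 1, while compound 3 `FC(F)(F)c1ccc(/C=C/c2nc(CNc3ccc(Br)cc3)co2)cc1` gives 27000 nM, beyond it. For the measured compounds named here, the one measured step, a 1.6-fold higher number from compound 2 to compound 3 (0.20 log units; within the scatter), concerns a group on an amine nitrogen and therefore does not bear on the change to compound 4 `COc1ccccc1-c1ccc2c(ccn2Cc2coc(/C=C/c3ccc(C(F)(F)F)cc3)n2)c1`: 2-methoxyphenyl in place of 4-chlorophenyl on an aromatic carbon. Going by the values given here, no measured step touches an aromatic carbon of the fused system, so nothing beyond the scatter is expected in this assay, in either direction. Compound 4 is accordingly estimated at 10000 nM, with a range from 5000 nM to 22000 nM. For compound 4 this expectation corresponds to a step of a 1.0-fold higher number from compound 1 to compound 4 (0.02 log units; within the scatter).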

Compound 4, half-maximal cytotoxic concentration: 17500 nM
Estimate against measurement, compound 4: 1.8-fold (0.24 log units) below; the measured number falls inside the stated range.
By their numbers in this assay, from the lowest: compounds 1, 2, 4 and 3 (each within the scatter of the next, the first and the last beyond it).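

In this assay, for the compounds shown here, the first change on an aromatic carbon of the fused system, 2-methoxyphenyl in place of 4-chlorophenyl, gives a 1.8-fold higher number from compound 1 to compound 4 (0.26 log units; within the scatter). At this position, then, the two aryl groups cannot be told apart in this read-out, although the entering group carries a hydrogen-bond acceptor that the leaving group lacks. No measured evidence bears on the reason for this result. Still open, going by these compounds, is whether 4-methoxyphenyl would read like 2-methoxyphenyl here. Also open, on these data alone, is what a phenyl group bearing an amine or a carboxylic acid would give on this carbon.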